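Swapping an Ether Link for an Amine Link

This account rests on a few compounds, and the source may have more. Where it says the series, first, only, none or still open, it means among the compounds named here.

Of the compounds shown here, three share one core and have been tested. Compound 1 `COc1cccc(Oc2ccc3cc(NC(=O)c4ccc(OC(C)=O)c(CC=C(C)C)c4)c(=O)oc3c2C)c1` gives 13700 nM in a functional assay on SK-BR-3 cells (Homo sapiens) for antiproliferative activity; on this read-out higher numbers stand for weaker inhibition and lower numbers for stronger inhibition. Compound 2 `COc1cccc(Oc2ccc3cc(NC(=O)c4ccc(O)c(CC=C(C)C)c4)c(=O)oc3c2C)c1` gives 33100 nM in this assay, and the step of a 2.4-fold higher number from compound 1 to compound 2 (0.38 log units; beyond the scatter) leaves compound 2 with the highest of the two plain numbers. Compound 3 `COc1cccc(Oc2ccc3cc(NC(=O)c4ccc(OC)c(-c5cccc(OC)c5)c4)c(=O)oc3c2C)c1` gives > 100000 nM in this assay, which is a limit of the assay rather than a number.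

Compound 4 `COc1ccc(Nc2ccc3cc(NC(=O)c4ccc(O)c(CC=C(C)C)c4)c(=O)oc3c2C)cc1` differs from compound 2 in one place: (4-methoxyphenyl)amino in place of 3-methoxyphenoxy on an aromatic carbon. Going by the values given here, no measured step touches this position. Among the compounds with values here, the one measured step, a 2.4-fold higher number from compound 1 to compound 2 (0.38 log units; beyond the scatter), concerns hydrogen in place of acetyl on an oxygen on an aromatic ring, and compound 4 keeps that part exactly as compound 2 has it. No measured comparison therefore speaks for a change in either direction, and the step of a 1.1-fold lower number from compound 2 to compound 4 (0.04 log units; within the scatter) is expected to stay within the scatter. Compound 4 is estimated to give 30000 nM in this assay, with a plausible range from 8000 nM to 100000 nM.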

Compound 4, half-maximal inhibitory concentration: > 100000 nM
Compound 4: a limit, no number; the forecaster's own chance of this, stated with the estimate: 25%; middle value at least 3.3-fold (0.52 log units) from the limit.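

This position on the shared core, untouched by any earlier step, turns out to matter: (4-methoxyphenyl)amino in place of 3-methoxyphenoxy gives an at least 3.0-fold higher number from compound 2 to compound 4 (0.48 log units; beyond the scatter) in this assay. The two groups have the same count of heavy atoms, yet two things change in this one step: a nitrogen carrying a hydrogen-bond donor replaces the ether oxygen as the link, and the methoxy group goes from the 3 to the 4 place on its ring. Compound 4 stands at a limit of the assay, so the full size of the step stays unknown: the limit of > 100000 nM in this assay, at which 2 of the 4 values shown sit.

From the compounds shown here alone, whether the weaker inhibition follows the amine link or the moved methoxy group stays open. A (3-methoxyphenyl)amino group or a 4-methoxyphenoxy group at this position would tell the two apart.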